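Adding a phenyl to compound 1: expected potency gain

The source may report more compounds than this note shows. Statements on the series, on what has been measured and on what is new or still open speak of the compounds shown alone.

Compound 1 `CC(Oc1ccccc1)C1=NCCN1` is measured in an assay on membranes from kidney (Oryctolagus cuniculus) for displacement of a labelled ligand from Monoamine oxidase (Homo sapiens) (on this read-out lower numbers stand for stronger inhibition and higher numbers for weaker inhibition), at 2690 nM, the second highest of three numbers. Compound 2 `CC(Oc1ccccc1Cc1ccccc1)C1=NCCN1` gives 7590 nM, and compound 3 `CC(Oc1cccc(-c2ccccc2)c1)C1=NCCN1` gives 269 nM. The change to compound 4 `CC(Oc1ccc(-c2ccccc2)cc1)C1=NCCN1` is phenyl in place of hydrogen on an aromatic carbon. Going by the values given here, two steps bear on it: a 2.8-fold higher number from compound 1 to compound 2 (0.45 log units; beyond the scatter), and a 10-fold lower number from compound 1 to compound 3 (1.00 log units; beyond the scatter). Among the compounds with values here, compound 3 shows that a phenyl on this ring can help, although its phenyl sits at a different aromatic carbon from the one in compound 4, so the size of the effect cannot be copied directly. A step of a 3.4-fold lower number from compound 1 to compound 4 (0.53 log units; beyond the scatter) is therefore expected, in the direction of stronger inhibition. Compound 4 is estimated at 800 nM, with a range from 200 nM to 3000 nM.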

Compound 4, inhibition constant: 182 nM
Compound 4: middle estimate off by 4.4-fold (0.64 log units), on the high side; the whole stated range lies above it.
By their numbers in this assay, from the lowest: compounds 4 and 3 (each within the scatter of the next); then compound 1; then compound 2.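

On the aromatic carbon para to a group of 8 heavy atoms, phenyl in place of hydrogen gives a 15-fold lower number from compound 1 to compound 4 (1.17 log units; beyond the scatter), a large gain in inhibition. Compound 3 at 269 nM and compound 4 at 182 nM lie within the scatter of each other, so these two phenyl placements cannot be told apart here, while compound 2, with its benzyl, goes against the gain. Nothing available explains this gain.

Going by these compounds, whether a smaller group, such as methyl, would give a similar gain at this carbon remains open. So does the effect of an amine or a carboxylic acid on the added phenyl.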